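The source may hold more compounds than are shown below. What is called first, only, known or untested is meant among the compounds shown, and "the series" means these compounds.

In an assay (Rattus norvegicus) for inhibition of Fatty-acid amide hydrolase 1 (Homo sapiens) (a lower number here means a stronger inhibitor, a higher number a weaker inhibitor), the three measured compounds stand as follows: compound 1 `O=C(CCCCCCc1ccccc1)c1ncc(-c2ccccc2F)o1` gives 110 nM; compound 2 `O=C(CCCCCCc1ccccc1)c1ncc(-c2cccc(O)c2)o1` gives 50 nM; compound 3 `O=C(CCCCCCc1ccccc1)c1ncc(-c2cccc(C(=O)C(F)(F)F)c2)o1` gives 16 nM.

Compound 3 holds the lowest of the three numbers, with compound 2 nearest and compound 1 furthest. Compound 4 `N#Cc1cccc(-c2cnc(C(=O)CCCCCCc3ccccc3)o2)c1` differs from compound 3 by cyano in place of (trifluoromethyl)carbonyl on an aromatic carbon. Two measured steps at this same aromatic carbon bear on the change: a 2.2-fold lower number from compound 1 to compound 2 (0.34 log units; beyond the scatter) and a 3.1-fold lower number from compound 2 to compound 3 (0.49 log units; beyond the scatter), both modest. Since the step in which hydroxy gave way to (trifluoromethyl)carbonyl lowered the number, taking that group away again is expected to raise it by a modest amount, a 3.1-fold higher number from compound 3 to compound 4 (0.49 log units; beyond the scatter). Compound 4 is therefore estimated at 50 nM, with a range from 15 nM to 160 nM.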

Compound 4, inhibition constant: 15 nM
Compound 4: the middle estimate sits 3.3-fold (0.52 log units) above what was measured, within the range that was stated.
By their numbers in this assay, from the lowest: compounds 4 and 3 (each within the scatter of the next); then compound 2; then compound 1.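

In this assay, the change to cyano at this aromatic carbon gives a 1.1-fold lower number from compound 3 to compound 4 (0.03 log units; within the scatter), so the (trifluoromethyl)carbonyl group is not required to hold the number at this level, and cyano, with fewer heavy atoms, serves as well. Against hydroxy, cyano gives a 3.3-fold lower number from compound 2 to compound 4 (0.52 log units; beyond the scatter), and the 3-cyanophenyl group in place of 2-fluorophenyl gives a 7.3-fold lower number from compound 1 to compound 4 (0.87 log units; beyond the scatter). No supporting data bear on why these two groups match here.

From the compounds shown here alone, whether a carboxylic acid or an amine at this same carbon would stay level with them remains open. So does whether the match between cyano and (trifluoromethyl)carbonyl would survive a shorter chain.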